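Swapping the carbamate cap for an alkyl amide

This account rests on a few compounds, and the source may have more. Where it says the series, first, only, none or still open, it means among the compounds named here.

The compounds here are short peptide-like chains tested in an assay on isolated protein for inhibition of cathepsin D (Bos taurus); on this read-out higher numbers stand for weaker inhibition and lower numbers for stronger inhibition. Compound 1, `CC(C)CCNC(=O)[C@H](C)NC(=O)C[C@H](C)[C@H](CC(C)C)NC(=O)[C@@H](NC(=O)[C@@H](NC(=O)OC(C)(C)C)C(C)C)C(C)C`, has repeat entries and gives 620 nM; 2000 nM (2 entries); these repeats, (the several entries of compound 1 in this assay, 620 nM; 2000 nM (2 entries)), show how far two runs of the same compound can drift apart. Compound 2, `COC(=O)[C@H](C)NC(=O)C[C@H](O)[C@H](CC(C)C)NC(=O)[C@@H](NC(=O)[C@@H](NC(=O)CC(C)C)C(C)C)C(C)C`, gives 90 nM. Compound 3, `CC(C)CCNC(=O)[C@H](C)NC(=O)C[C@H](O)[C@H](CC(C)C)NC(=O)[C@@H](NC(=O)OC(C)(C)C)C(C)C`, gives 2700 nM, the highest of the two single numbers recorded, and its nearest neighbour, compound 2, sits well beyond the usual scatter below it. Compounds 2 and 3 differ in several places at once, so their gap cannot be tied to any one change.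

Compound 4, `CCC(C)C(=O)N[C@H](C(=O)N[C@@H](CC(C)C)[C@@H](O)CC(=O)N[C@@H](C)C(=O)NCCC(C)C)C(C)C`, has not yet been measured. It differs from compound 3 in one spot: sec-butyl in place of tert-butoxy on a carbonyl carbon. The carbamate cap on the chain end thus becomes a plain alkyl amide of roughly the same size. No comparable single change has been measured among these compounds, so there is no direct precedent. The step from compound 3 to compound 4 is expected to be small, a 1.8-fold lower number from compound 3 to compound 4 (0.26 log units; within the scatter), leaning toward somewhat stronger inhibition but possibly staying within scatter. Compound 4 is therefore expected to give 1500 nM, with a likely range from 400 nM to 6000 nM.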

Compound 4, inhibition constant: 230 nM
Estimate against measurement, compound 4: 6.5-fold (0.81 log units) above; measured number below the stated range.
By their numbers in this assay, from the lowest: compound 2; then compound 4; then compound 3.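

Replacing tert-butoxy with sec-butyl on this carbonyl carbon gives a 12-fold lower number from compound 3 to compound 4 (1.07 log units; beyond the scatter) in this assay, so the end of the chain is not a passive cap: a single swap here can clearly change the inhibition of the enzyme. Neither group has a ring, a net charge or a hydrogen-bond donor, and the clearest difference in what is counted is the oxygen that leaves with tert-butoxy, but this one pair cannot separate the loss of that oxygen from the change in how the carbon atoms are arranged. The step is also wider than the spread between repeat entries of a single compound, which gives a practical yardstick for reading it: the several entries of compound 1 in this assay, 620 nM; 2000 nM (2 entries).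

As far as these compounds go, what remains open is whether sec-butyl is itself especially favourable or whether other carbon groups on this carbonyl carbon, such as methyl, phenyl or a longer chain like n-hexyl, would give similar numbers. An ether-bearing group such as methoxymethyl in the same place would help show whether the oxygen or the shape of the group drives the step.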